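The source may report more compounds than this note shows. Statements on the series, on what has been measured and on what is new or still open speak of the compounds shown alone.

Three compounds of one shared core are in hand, and a fourth awaits measurement. Compound 1 `CC(C)(C)c1ccc(C(=O)N2CCC3(CC2)C(=O)N(CC(=O)N2CCN(S(C)(=O)=O)CC2)CN3c2ccccc2)cc1` carries a tert-butyl-substituted benzoyl group on the core and a methanesulfonylpiperazine amide on the side chain. Compound 2 `COC(=O)CCCNC(=O)CN1CN(c2ccccc2)C2(CCN(C(=O)c3ccc(C4CCCCC4)cc3)CC2)C1=O` pairs a cyclohexyl-substituted benzoyl group with a methyl ester chain on the amide nitrogen. Compound 3 `COC(=O)CCCNC(=O)CN1CN(c2ccccc2)C2(CCN(C(=O)c3ccc(C(C)(C)C)cc3)CC2)C1=O` keeps that ester chain but returns to the tert-butyl group; for it no result was reported.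

In an assay on HEK293 cells for displacement of a labelled ligand from NPC1-like intracellular cholesterol transporter 1 (Homo sapiens) (on this read-out lower numbers stand for stronger inhibition and higher numbers for weaker inhibition), compound 1 gives 19000 nM, while compound 2 gives 2500 nM. For compound 3 the entry in this assay reads "not determined" (no result reported). Of the two numbers available, compound 2 stands at the lower one, and the gap to compound 1 lies beyond the usual scatter of this assay.

Compound 4 `NCCNC(=O)CN1CN(c2ccccc2)C2(CCN(C(=O)c3ccc(C4CCCCC4)cc3)CC2)C1=O` differs from compound 2 in one place: amino in place of (methoxycarbonyl)methyl on a saturated chain carbon, two bonds along the chain from an amide-type nitrogen. Among the compounds with values here, no measured pair in this set tracks that particular change, so its effect is not known from these data. With the ester chain removed and only a small amino group remaining, the author expects a step from compound 2 to compound 4 in this assay that is modest, a 1.8-fold higher number from compound 2 to compound 4 (0.26 log units; within the scatter), and most likely toward a somewhat higher number, though a change within the scatter cannot be excluded. Compound 4 is therefore estimated at 4500 nM, within a range of 1300 nM to 15000 nM.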

Compound 4, half-maximal inhibitory concentration: 3800 nM
For compound 4 the middle estimate is 1.2-fold (0.07 log units) above the measured one; measured number inside the range.
By their numbers in this assay, from the lowest: compounds 2 and 4 (each within the scatter of the next); then compound 1.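

In this assay, within the data shown here, replacing (methoxycarbonyl)methyl with amino on a saturated chain carbon, two bonds along the chain from an amide-type nitrogen, gives a 1.5-fold higher number from compound 2 to compound 4 (0.18 log units; within the scatter), the first measured step at this position. In this one pair, the group that leaves, with 5 heavy atoms, 2 hydrogen-bond acceptors and no hydrogen-bond donor, gives way to one with 1 heavy atom and 1 hydrogen-bond donor, and compound 4 still stands within the scatter of compound 2. The data on hand offer no explanation for this result.

The compounds shown leave open whether a carboxylic acid at the end of the chain, a longer chain ending in an amine, or a dimethylamino group in place of amino would also stay within the scatter of compound 2. They also leave open whether the same exchange would read alike with tert-butyl in place of cyclohexyl on the benzoyl group, and whether any chain at this position can reach clearly lower numbers than compound 2 at 2500 nM in this assay.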